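The source may report more compounds than this note shows. Statements on the series, on what has been measured and on what is new or still open speak of the compounds shown alone.

In an ADME assay on J774.1 cells (Mus musculus) for cytotoxicity, read by resazurin assay, with a stated time of 48 h (on this read-out lower numbers stand for stronger inhibition and higher numbers for weaker inhibition), compound 1 `CCCCn1cc(C(=O)O)c(=O)c2cc(F)c(N3CCC(C(N)=O)CC3)cc21` gives > 100000 nM, which is a limit and not a number. Compound 2 `NC(=O)C1CCN(c2cc3c(cc2F)c(=O)c(C(=O)O)cn3C2CC2)CC1` also gives only a limit, > 100000 nM. Compound 3 `CCCCn1cc(C(=O)O)c(=O)c2cc(F)c(N(C)C)cc21` gives only a limit too, > 100000 nM. The whole set therefore rests on (the limit of > 100000 nM in this assay, at which 3 of the 3 values shown sit).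

Compound 4 `CCCCn1cc(C(=O)NCc2ccc(O)cc2)c(=O)c2cc(F)c(N3CCC(C(N)=O)CC3)cc21` keeps the core of compound 1 and differs in one place: (4-hydroxybenzyl)amino in place of hydroxy on a carbonyl carbon. The same difference, cut one bond further out, reads carboxy to (4-hydroxybenzyl)carbamoyl.

The measured steps that start from compound 1 are a step that the two limits leave unreadable from compound 1 to compound 2 and a step that the two limits leave unreadable from compound 1 to compound 3. Neither has a readable size, and neither changes the group on the carbonyl carbon, so they supply no measured size to carry over. A small move toward stronger inhibition is expected, though another reading at the limit remains quite possible. The expected change is an at least 1.4-fold lower number from compound 1 to compound 4 (0.15 log units; that floor lies within the scatter). Compound 4 is estimated at 70000 nM, with an expected range of 20000 nM to 150000 nM.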

Compound 4, half-maximal inhibitory concentration: 41600 nM
The estimate for compound 4 lay 1.7-fold (0.23 log units) above the measured number; measured number inside the range.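

In this assay, within the data shown here, the change from hydroxy to (4-hydroxybenzyl)amino on the carbonyl carbon gives an at least 2.4-fold lower number from compound 1 to compound 4 (0.38 log units; beyond the scatter) and is the first change in the set to bring the read-out off the limit. Compound 1 itself gives > 100000 nM which is a limit and not a number. The step thus has only a floor, the other two steps from compound 1 cannot be read, and the set still leans on one limit: the limit of > 100000 nM in this assay, at which 3 of the 4 values shown sit.

As far as these compounds go, it remains open whether the ring hydroxy of the entering group counts, which a plain benzylamino or a 4-methoxybenzylamino group on the same carbonyl carbon would address. Also open, from the compounds shown here alone, is whether (4-hydroxybenzyl)amino gives a similar step on the core of compound 2, which carries cyclopropyl in place of butyl.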